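Chain extension at the aromatic nitrogen: compounds 1 to 4

The source may hold more compounds than are shown below. What is called first, only, known or untested is meant among the compounds shown, and "the series" means these compounds.

Compound 1 `CN(C)CCn1c(-c2cncc(-c3cc4cc(O)ccc4[nH]3)c2)cc2cc(O)ccc21` gives 5760 nM in a functional assay on CCRF-CEM cells (Homo sapiens) for cytotoxicity; on this read-out higher numbers stand for weaker inhibition and lower numbers for stronger inhibition. Compound 2 `CN(C)CCCn1c(-c2cncc(-c3cc4cc(O)ccc4[nH]3)c2)cc2cc(O)ccc21` carries (dimethylamino)methyl in place of dimethylamino on a saturated chain carbon, two bonds along the chain from an aromatic nitrogen and gives 14200 nM in this assay, so that the step is a 2.5-fold higher number from compound 1 to compound 2 (0.39 log units; beyond the scatter). Compound 3 `CN(C)CCCOc1ccc(-c2cncc(-c3cc4cc(O)ccc4n3CCN(C)C)c2)cc1` has a different core; the difference between the two cores is not broken down here. In this assay compound 3 gives 59300 nM, the highest number of the three measured, with compound 2 nearest and compound 1 furthest.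

Compound 4 `CN(C)CCCOc1ccc(-c2cncc(-c3cc4cc(O)ccc4n3CCCN(C)C)c2)cc1` is not yet measured. It differs from compound 3 by (dimethylamino)methyl in place of dimethylamino on a saturated chain carbon, two bonds along the chain from an aromatic nitrogen, the same change as that from compound 1 to compound 2, at the same place. The expected step from compound 3 to compound 4 in this assay is a 2.2-fold higher number from compound 3 to compound 4 (0.34 log units; beyond the scatter), which rests on the measured 2.5-fold higher number from compound 1 to compound 2 (0.39 log units; beyond the scatter) and on the fact that compound 3 already stands at 59300 nM, the highest number of the three measured. Compound 4 is therefore estimated at 130000 nM, within 50000 nM to 300000 nM.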

Compound 4, half-maximal inhibitory concentration: 12700 nM
Compound 4: middle estimate off by 10-fold (1.01 log units), on the high side, and the stated range ends above it.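

In this assay the change gives a 4.7-fold lower number from compound 3 to compound 4 (0.67 log units; beyond the scatter), and its direction does not carry over from the other core: the same change on two cores in this assay, a 2.5-fold higher number (0.39 log units; beyond the scatter) from compound 1 to compound 2 and a 4.7-fold lower number (0.67 log units; beyond the scatter) from compound 3 to compound 4, 12-fold (1.06 log units) apart, beyond the scatter of two such steps

So within this series, the effect of replacing dimethylamino with (dimethylamino)methyl on the saturated chain carbon cannot be transferred from one core to the other, and a step measured on one core gives no safe forecast for the other. Within the data shown here, the comparison rests on only one pair per core, so it does not show why the direction differs, which part of the difference between the cores matters, or how other cores would behave.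

Still open, as far as these compounds go, is whether a longer chain, such as 4-(dimethylamino)butyl, would continue either step on its core. Also open, from the compounds shown here alone, is whether a cyclic amine such as pyrrolidine, or a primary amine, at the end of the chain would show the same dependence on the core.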